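From Chloro to Hydroxy on a Shared Core

The compounds below may be only part of what the source reports. "The series", "measured", "known", "first", "only" and "open" are said of these compounds alone.

In an ADME assay on MIA PaCa-2 cells (Homo sapiens) for cytotoxicity, read by MTT assay, with a stated time of 72 h (on this read-out higher numbers stand for weaker inhibition and lower numbers for stronger inhibition), compound 1 `COc1ccc(C2=C(c3cc(OC)c(OC)c(OC)c3)C(=O)C(OC(C)=O)C2)cc1OC(C)C` gives > 100 ug/mL, which is a limit of the assay and not a number. Compound 2 `COc1ccc(C2=C(c3cc(OC)c(OC)c(OC)c3)C(=O)C(OC(C)=O)C2)cc1F` gives 39.5 ug/mL, and compound 3 `COc1ccc(C2=C(c3cc(OC)c(OC)c(OC)c3)C(=O)C(OC(C)=O)C2)cc1Cl` gives 24 ug/mL. Compound 3 thus stands level with compound 2, as a 1.6-fold lower number from compound 2 to compound 3 (0.22 log units; within the scatter) lies within the scatter.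

Compound 4 `COc1ccc(C2=C(c3cc(OC)c(OC)c(OC)c3)C(=O)C(OC(C)=O)C2)cc1O` carries hydroxy in place of chloro on an aromatic carbon, ortho to a methoxy group: hydroxy in place of chloro on an aromatic carbon. Three measured steps at this same place bear on the change. Exchanging the two halogens gave only a 1.6-fold lower number from compound 2 to compound 3 (0.22 log units; within the scatter). Among the measured compounds shown here, replacing isopropoxy, the one oxygen-linked group measured so far, gave larger steps: an at least 2.5-fold lower number from compound 1 to compound 2 (0.40 log units; beyond the scatter) and an at least 4.1-fold lower number from compound 1 to compound 3 (0.61 log units; beyond the scatter). Hydroxy is also oxygen-linked, so the upper end of the range stays open towards the limit. No step beyond the scatter is expected in this assay, and the estimated change is a 1.2-fold lower number from compound 3 to compound 4 (0.08 log units; within the scatter). Compound 4 is expected at 20 ug/mL, with an estimated range from 4 ug/mL to 90 ug/mL.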

Compound 4, half-maximal inhibitory concentration: 18.5 ug/mL
The estimate for compound 4 lay 1.1-fold (0.03 log units) above the measured number; measured number inside the range.
By their numbers in this assay, from the lowest: compounds 4, 3 and 2 (each within the scatter of the next, the first and the last beyond it). At a limit, above all of these: compound 1.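

In this assay the hydroxy of compound 4 shows that an oxygen-linked group at this place need not end at a limit, as the isopropoxy of compound 1 does, with hydrogen in place of isopropyl giving an at least 5.4-fold lower number from compound 1 to compound 4 (0.73 log units; beyond the scatter). That step is a bound and not a measured size, since compound 1 stands at a limit of the assay: the limit of > 100 ug/mL in this assay, at which 1 of the 4 values shown sits.

Against the halogens, hydroxy gives a 1.3-fold lower number from compound 3 to compound 4 (0.11 log units; within the scatter), yet a 2.1-fold lower number from compound 2 to compound 4 (0.33 log units; beyond the scatter), so it matches chloro but only modestly exceeds fluoro.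

The compounds shown leave open how an amine or a carboxylic acid at this place would read, and whether ethoxy would stay with hydroxy or fall to a limit with isopropoxy. They also give no cause for the gap between hydroxy and isopropoxy.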